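A few compounds are considered here, and "the series" means these few. Any claim that something is new, unique, unknown or untested is made for them only; others in the source may bear on it.

Working notes on the series. Compound 1 `COc1cc(CNC(=O)CCCCCCC(C)C)ccc1OCCCCOc1ccc(C(N)=S)cc1` and compound 3 `COc1cc(CNC(=O)CCCC/C=C/C(C)C)ccc1OCCCCOc1ccc(C(N)=S)cc1` share one core and differ only in the chain of the amide; compound 2 `COc1cc(CNC(=O)CCCCCCC(C)C)ccc1OC(=O)CCC(=O)Oc1ccc(-c2cc(=S)ss2)cc1` and compound 4 `COc1cc(CNC(=O)CCCC/C=C/C(C)C)ccc1OC(=O)CCC(=O)Oc1ccc(-c2cc(=S)ss2)cc1` share a second core, and the difference between the two cores is not broken down here. In a functional assay on MCF7 cells (Homo sapiens) for antiproliferative activity, read by MTT assay, with a stated time of 48 h (a higher number here means a weaker inhibitor, a lower number a stronger inhibitor), compound 1 gives 4990 nM, compound 3 gives 49800 nM, and compound 2 gives 2560 nM. Compound 2 and compound 1 lie within the scatter of each other in this assay, while compound 3 sits beyond the scatter from both of them. Going by the values given here, the single change measured so far is 3-methylbut-1-en-1-yl in place of isopentyl on a saturated chain carbon, four bonds along the chain from a carbonyl carbon, which gave a 10-fold higher number from compound 1 to compound 3 (1.00 log units; beyond the scatter). Compound 4 carries the same change on the second core: 3-methylbut-1-en-1-yl in place of isopentyl on a saturated chain carbon, four bonds along the chain from a carbonyl carbon. Among the compounds with values here, only one instance of this change has been measured, so the expectation for the second instance rests on it alone. Within the data shown here, the expected step of an 8.6-fold higher number from compound 2 to compound 4 (0.93 log units; beyond the scatter) is taken to be of about the same size as the measured one, because on the first core the same change gave a 10-fold higher number from compound 1 to compound 3 (1.00 log units; beyond the scatter), with wide room left for the single precedent. Compound 4 is thus estimated at 22000 nM in this assay, expected to fall between 7000 nM and 70000 nM.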

Compound 4, half-maximal inhibitory concentration: 2120 nM
Beside the measured number, compound 4's estimate is 10-fold (1.02 log units) above it, and the stated range ends above it.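

On the core of compound 2, the change from isopentyl to 3-methylbut-1-en-1-yl gives a 1.2-fold lower number from compound 2 to compound 4 (0.08 log units; within the scatter) in this assay, so no difference can be read from this step. The change therefore does not carry over from one core to the other with the same size, and the two steps differ: the same change on two cores in this assay, a 10-fold higher number (1.00 log units; beyond the scatter) from compound 1 to compound 3 and a 1.2-fold lower number (0.08 log units; within the scatter) from compound 2 to compound 4, 12-fold (1.08 log units) apart, beyond the scatter of two such steps This rests on one pair per core, so it shows that the result of this change is not transferable across these four compounds, but it does not show which part of the difference between the cores goes with the gap, nor how the change would behave on any further core.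

As far as these compounds go, it remains open whether the same split between the two cores would appear with a longer chain in place of either amide chain. From the compounds shown here alone, it also remains open whether it would persist with an amine or a carboxylic acid at the end of that chain.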